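Methoxy on the benzyl ring of the shared core

The source may report more compounds than this note shows. Statements on the series, on what has been measured and on what is new or still open speak of the compounds shown alone.

Two compounds of this series have numbers in a functional assay on DU-145 cells (Homo sapiens) for cytotoxicity, read by MTT assay; a higher number here means a weaker inhibitor, a lower number a stronger inhibitor. Compound 1 `COc1ccc2cc([C@H](C)c3nnc(SCc4ccccc4)n3-c3ccc(Cl)cc3)ccc2c1` gives 35800 nM in this assay. Compound 2 `COc1ccc2cc([C@H](C)c3nnc(SCc4c(Cl)cccc4Cl)n3-c3ccc(F)cc3)ccc2c1` differs from compound 1 in several places at once. In this assay compound 2 gives 12300 nM. Among the measured compounds shown here, compound 1 thus stands highest of the two numbers; the gap to compound 2 lies beyond the usual scatter, but as the two structures differ in several places at once no single step is read from that pair.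

Compound 3 `COc1cccc(CSc2nnc([C@@H](C)c3ccc4cc(OC)ccc4c3)n2-c2ccc(Cl)cc2)c1` has not yet been measured. It differs from compound 1 in one place: methoxy in place of hydrogen on an aromatic carbon. For the measured compounds named here, no measured pair in this set carries the same change, so nothing here tells how large a step it brings.

With only compound 1 as anchor, the expected step from compound 1 to compound 3 in this assay, a 1.2-fold lower number from compound 1 to compound 3 (0.08 log units; within the scatter), is set at none beyond the scatter. Compound 3 is therefore estimated at 30000 nM in this assay. For compound 3 the expected range runs from 12000 nM to 75000 nM.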

Compound 3, half-maximal inhibitory concentration: <= 400000 nM
Compound 3 gave a limit, no number (the forecaster's own chance of this, stated with the estimate: 20%); the middle value is on the limit's open side.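

In this assay, among the compounds shown here, compound 3 gives <= 400000 nM, which is a limit and not a number, so no step from compound 1 to compound 3 can be read. The compounds shown leave open whether (3-methoxybenzyl)sulfanyl in place of benzylsulfanyl on the shared core shifts the number in this assay at all, and in which direction.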